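Nitro for methoxy on the pyridine of compound 2

The compounds below may be only part of what the source reports. "The series", "measured", "known", "first", "only" and "open" are said of these compounds alone.

Compound 1 `c1cncc(N2CC[C@H]3CN[C@H]3C2)c1` carries the unsubstituted aromatic ring on the shared core, and in a functional assay on HEK293 cells for agonist activity at Neuronal acetylcholine receptor; alpha4/beta2 (Homo sapiens), read by FLIPR (a lower number here means that less compound is needed, a higher number that more compound is needed for the effect), compound 1 gives 71 nM. Compound 2 `COc1ccc(N2CC[C@H]3CN[C@H]3C2)cn1` adds a methoxy on that ring, and in this assay compound 2 gives 2200 nM. Compound 2 therefore stands at the highest of the two numbers measured, with compound 1 as its nearest neighbour; the change was a 31-fold higher number from compound 1 to compound 2 (1.49 log units; beyond the scatter).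

Compound 3 `O=[N+]([O-])c1ccc(N2CC[C@H]3CN[C@H]3C2)cn1` is the next variant: nitro in place of methoxy on an aromatic carbon. Among the measured compounds shown here, the only measured step that bears on this position is the one from hydrogen to methoxy, which was large, a 31-fold higher number from compound 1 to compound 2 (1.49 log units; beyond the scatter). For the measured compounds named here, no step from methoxy to another substituent at this place has been measured, so the direction of the exchange rests on nothing more than the fact that a substituent remains at the same place. A number in the region of compound 2 is expected, with a wide range on either side, and the step from compound 2 to compound 3 is estimated as a 1.8-fold lower number from compound 2 to compound 3 (0.26 log units; within the scatter). For compound 3 the estimate in this assay is 1200 nM, between 200 nM and 7000 nM.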

Compound 3, half-maximal effective concentration: 100 nM
For compound 3 the middle estimate is 12-fold (1.08 log units) above the measured one, and the stated range ends above it.
By their numbers in this assay, from the lowest: compounds 1 and 3 (each within the scatter of the next); then compound 2.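

In this assay, a group on this aromatic carbon, next to the ring nitrogen, does not by its presence alone raise the number: the exchange of methoxy for nitro gives a 22-fold lower number from compound 2 to compound 3 (1.34 log units; beyond the scatter) and thus reverses most of the earlier rise. Set against the unsubstituted ring, nitro gives a 1.4-fold higher number from compound 1 to compound 3 (0.15 log units; within the scatter) and so leaves compound 3 within the scatter of compound 1, whereas the methoxy step was a 31-fold higher number from compound 1 to compound 2 (1.49 log units; beyond the scatter) in the same assay. The outcome at this place therefore depends on which group stands there, though nothing available accounts for the difference between methoxy and nitro.

With only hydrogen, methoxy and nitro at this place, the compounds shown do not tell whether the high number of compound 2 is particular to methoxy or would recur with a longer ether such as ethoxy, an amine or a carboxylic acid. They also leave open whether nitro would be tolerated in the same way elsewhere on the ring, and whether any group at this place could bring the number clearly below that of compound 1.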